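Sulfonyl to sulfanyl swap in a small growth-inhibition series

The source may report more compounds than this note shows. Statements on the series, on what has been measured and on what is new or still open speak of the compounds shown alone.

Measured in a functional assay on DU-145 cells (Homo sapiens) for inhibition, read by trypan blue exclusion, with a stated time of 96 h; a lower number here means a stronger inhibitor of growth, a higher number a weaker inhibitor of growth:
- compound 1 `Cc1ccc(S/C(=C/c2ccc(Cl)cc2)C(=O)c2ccc(Br)cc2)cc1`: 10000 nM
- compound 2 `CSc1ccc(/C=C(/Sc2ccc(C)cc2)C(=O)c2ccc(Br)cc2)cc1`: 50000 nM
- compound 3 `Cc1ccc(S(=O)(=O)/C(=C/c2ccc(N(C)C)cc2)C(=O)c2ccc(Br)cc2)cc1`: 50000 nM

Compound 3 gives 50000 nM, the same number as compound 2 at 50000 nM. Together these are the highest of the three numbers, while compound 1 gives 10000 nM.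

Compound 4 `Cc1ccc(S/C(=C/c2ccc(N(C)C)cc2)C(=O)c2ccc(Br)cc2)cc1` differs from compound 3 by one change, ((4-methylphenyl)sulfanyl in place of (4-methylphenyl)sulfonyl on a double-bonded chain carbon bound to a carbonyl carbon and a double-bonded chain carbon), on a double-bonded chain carbon bound to a carbonyl carbon and a double-bonded chain carbon.

For the measured compounds named here, no measured pair isolates this change. Going by the values given here, the only measured step, a 5.0-fold higher number from compound 1 to compound 2 (0.70 log units; beyond the scatter), lies at another place in the structure, so it offers a guide to size and none to direction. Compound 1 and compound 2 both carry (4-methylphenyl)sulfanyl, and their numbers span the whole measured range, so the group alone does not fix a value. Compound 4 therefore has its expected value placed inside that range, with a wide margin.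

The expected step is a 2.5-fold lower number from compound 3 to compound 4 (0.40 log units; beyond the scatter), an estimated modest move towards a lower number in this assay, smaller than the measured one.

For compound 4 the estimated value is 20000 nM, with an expected range of 6000 nM to 60000 nM.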

Compound 4, concentration for 50% growth inhibition: > 100000 nM
Compound 4 gave a limit, no number; the forecaster's own chance of this, stated with the estimate: 10%; middle value at least 5.0-fold (0.69 log units) away from the limit.
By their numbers in this assay, from the lowest: compound 1; then compounds 2 and 3 (each within the scatter of the next). At a limit, above all of these: compound 4.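

In this assay compound 4 gives > 100000 nM, a limit of the assay and not a number: the limit of > 100000 nM in this assay, at which 1 of the 4 values shown sits.

For the compounds shown here, this is the first pair that isolates the change on a double-bonded chain carbon bound to a carbonyl carbon and a double-bonded chain carbon: (4-methylphenyl)sulfanyl in place of (4-methylphenyl)sulfonyl gives an at least 2.0-fold higher number from compound 3 to compound 4 (0.30 log units; that floor lies within the scatter), so with dimethylamino in the compound the sulfanyl form shows no move towards a lower number, though a real rise is not established by that floor. With (4-methylphenyl)sulfanyl held constant, the group on the aromatic carbon also carries weight, since dimethylamino in place of chloro gives an at least 10-fold higher number from compound 1 to compound 4 (1.00 log units; beyond the scatter), while dimethylamino in place of methylsulfanyl gives an at least 2.0-fold higher number from compound 2 to compound 4 (0.30 log units; that floor lies within the scatter), a floor that separates those two groups less clearly.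

Going by these compounds, the true size of all three steps remains open, as does whether the sulfonyl and sulfanyl forms would compare in the same way with chloro or methylsulfanyl on the aromatic carbon. On these data alone, how a methoxy group or a primary amine on the aromatic carbon, or a sulfinyl link at the chain carbon, would read in this assay also stays open.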